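A few compounds are considered here, and "the series" means these few. Any claim that something is new, unique, unknown or untested is made for them only; others in the source may bear on it.

Three compounds sharing one core, each with a phenyl group on the ring nitrogen of the fused system, have been measured in an ADME assay on HT-29 cells (Homo sapiens) for cytotoxicity, read by MTT assay, with a stated time of 72 h; a lower number here means a stronger inhibitor, a higher number a weaker inhibitor. Compound 1 `C=CC(=O)Nc1cc(Nc2ncc3ncn(-c4ccccc4)c3n2)c(OC)cc1N(C)CCN(C)C` gives 8080 nM. Compound 2 `C=CC(=O)Nc1cc(Nc2ncc3ncn(-c4ccccc4Cl)c3n2)c(OC)cc1N(C)CCN(C)C` gives 11300 nM. Compound 3 `C=CC(=O)Nc1cc(Nc2ncc3ncn(-c4ccc(Cl)cc4Cl)c3n2)c(OC)cc1N(C)CCN(C)C` gives 20600 nM, the highest of the three numbers, though only its distance from compound 1 stands beyond the scatter.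

Two single changes connect them, each a chloro in place of hydrogen on an aromatic carbon: a 1.4-fold higher number from compound 1 to compound 2 (0.15 log units; within the scatter) and a 1.8-fold higher number from compound 2 to compound 3 (0.26 log units; within the scatter). Together they add up to a 2.5-fold higher number from compound 1 to compound 3 (0.41 log units; beyond the scatter).

Compound 4 `C=CC(=O)Nc1cc(Nc2ncc3ncn(-c4ccc(F)c(Cl)c4)c3n2)c(OC)cc1N(C)CCN(C)C` differs from compound 3 by 3-chloro-4-fluorophenyl in place of 2,4-dichlorophenyl on an aromatic nitrogen. The count of halogen atoms stays at two, one chlorine giving way to one fluorine and the pattern on the ring shifting. Among the measured compounds shown here, the measured steps show that adding chlorine to this phenyl changed the read-out only a little, and no measured pair tells what removing a chlorine or adding a fluorine does. The step from compound 3 to compound 4 is therefore expected to be small, a 1.5-fold lower number from compound 3 to compound 4 (0.17 log units; within the scatter), sitting within the scatter. In this assay compound 4 is expected to give about 14000 nM, with a plausible range from 6000 nM to 35000 nM.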

Compound 4, half-maximal inhibitory concentration: 1610 nM
Estimate against measurement, compound 4: 8.7-fold (0.94 log units) above; the whole stated range lies above it.
By their numbers in this assay, from the lowest: compound 4; then compounds 1, 2 and 3 (each within the scatter of the next, the first and the last beyond it).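

In this assay, the group on the aromatic nitrogen proves able to move the number much further than the chlorine steps suggested: there is a 13-fold lower number from compound 3 to compound 4 (1.11 log units; beyond the scatter) when one two-halogen phenyl replaces another of equal heavy-atom count. The new group also separates compound 4 from the two compounds with fewer halogens, with a 7.0-fold lower number from compound 2 to compound 4 (0.85 log units; beyond the scatter) and a 5.0-fold lower number from compound 1 to compound 4 (0.70 log units; beyond the scatter) on record, so halogens on this phenyl do not push the number one way, as compound 3 stands above compound 1 while compound 4 stands below it. This single step swaps a chlorine for a fluorine and shifts the pattern on the ring at once, so the two changes cannot be told apart, and no measured evidence is at hand to explain the result.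

The compounds shown leave open whether 3-chlorophenyl or 4-fluorophenyl alone would give a number close to that of compound 4, which would show which halogen carries the step. They also leave open how this position would respond to a phenyl bearing a nitrile, a methoxy group or an amine in place of halogen.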